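A few compounds are considered here, and "the series" means these few. Any claim that something is new, unique, unknown or untested is made for them only; others in the source may bear on it.

Of the compounds shown here, two with a shared core have been measured in an assay on HeLa cells for inhibition of MAP kinase-interacting serine/threonine-protein kinase 1/2 (Homo sapiens), read by AlphaScreen, with a stated time of 2 h; a higher number here means a weaker inhibitor, a lower number a stronger inhibitor. Compound 1 `CNC(=O)c1cncc(-c2ccc(C(N)=O)c(OC(C)C)c2)c1` gives 1900 nM in this assay. Compound 2 `CC(C)Oc1cc(-c2cncc(-c3c[nH]nc3C3CC3)c2)ccc1C(N)=O` gives 370 nM, the lowest of the two numbers; the step of a 5.1-fold lower number from compound 1 to compound 2 (0.71 log units; beyond the scatter) lies beyond the scatter and is modest in size. Compound 3 `CC(C)Oc1cc(-c2cncc(-c3cnn(C(C)C)c3)c2)ccc1C(N)=O` has not yet been measured in this assay. It differs from compound 2 in one place: 1-isopropyl-1H-pyrazol-4-yl in place of 3-cyclopropyl-1H-pyrazol-4-yl on an aromatic carbon. For the measured compounds named here, no measured step speaks directly to this change, since the single known step only compares methylcarbamoyl with 3-cyclopropyl-1H-pyrazol-4-yl and leaves both pyrazoles untested against each other. The change removes the one hydrogen-bond donor counted above, so some weakening seems the more likely outcome, but the size is uncertain. For compound 3 the expected step is a 2.2-fold higher number from compound 2 to compound 3 (0.33 log units; beyond the scatter), giving an estimate of 800 nM with a range from 250 nM to 2500 nM.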

Compound 3, half-maximal inhibitory concentration: 940 nM
Estimate against measurement, compound 3: 1.2-fold (0.07 log units) below, within the range that was stated.
By their numbers in this assay, from the lowest: compound 2; then compound 3; then compound 1.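

At this position on the six-membered aromatic ring with 1 nitrogen, the two pyrazoles can now be compared directly: in this assay, the change gives a 2.5-fold higher number from compound 2 to compound 3 (0.40 log units; beyond the scatter), so 1-isopropyl-1H-pyrazol-4-yl, with the same heavy-atom count but no hydrogen-bond donor, is modestly weaker than 3-cyclopropyl-1H-pyrazol-4-yl. It still improves on methylcarbamoyl, with a 2.0-fold lower number from compound 1 to compound 3 (0.31 log units; beyond the scatter), so both pyrazoles shown give lower numbers than methylcarbamoyl at this place. Nothing available explains the difference between the two pyrazoles.

The step removes the hydrogen-bond donor and the cyclopropyl ring together, so these compounds cannot separate the two changes. As far as these compounds go, whether 1-methyl-1H-pyrazol-4-yl, 3-isopropyl-1H-pyrazol-4-yl or a simple amine would fit this place remains open.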